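Methoxy in Place of Methylamino on a Shared Urea Core

A few compounds are considered here, and "the series" means these few. Any claim that something is new, unique, unknown or untested is made for them only; others in the source may bear on it.

Compound 1 `O=C(Nc1ccc(-n2ncc3c(Cl)cccc32)cc1)Nc1ccc(Cl)c(C(F)(F)F)c1`: 2500 nM
Compound 2 `Cc1cccc2c1cnn2-c1ccc(NC(=O)Nc2ccc(Cl)c(C(F)(F)F)c2)cc1`: 6700 nM
Compound 3 `CNc1cccc2c1cnn2-c1ccc(NC(=O)Nc2ccc(Cl)c(C(F)(F)F)c2)cc1`: 5000 nM

In a functional assay on Bel-7402 cells (Homo sapiens) for cytotoxicity, read by MTT assay, with a stated time of 72 h (a higher number here means a weaker inhibitor, a lower number a stronger inhibitor), these three compounds carry the numbers above. Compound 3 holds the second highest number of the three, yet the steps of a 1.3-fold lower number from compound 2 to compound 3 (0.13 log units; within the scatter) and a 2.0-fold higher number from compound 1 to compound 3 (0.30 log units; within the scatter) both stay within the scatter, so compound 3 is not separable from either neighbour. Among the compounds with values here, only the step of a 2.7-fold higher number from compound 1 to compound 2 (0.43 log units; beyond the scatter) reaches beyond the scatter, and it is modest.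

Compound 4 `COc1cccc2c1cnn2-c1ccc(NC(=O)Nc2ccc(Cl)c(C(F)(F)F)c2)cc1` differs from compound 3 in one place: methoxy in place of methylamino on an aromatic carbon. The changes made earlier at this same position moved the numbers little, so a small step is expected, no change at the digits printed from compound 3 to compound 4 (within the scatter). Compound 4 is therefore estimated to give 5000 nM, with a range from 2000 nM to 12500 nM.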

Compound 4, half-maximal inhibitory concentration: 2900 nM
Compound 4: middle estimate off by 1.7-fold (0.24 log units), on the high side; the range from low to high includes it.
By their numbers in this assay, from the lowest: compounds 1, 4, 3 and 2 (each within the scatter of the next, the first and the last beyond it).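

Methoxy, like chloro, stands apart from methyl at this position, though only modestly, with a 2.3-fold lower number from compound 2 to compound 4 (0.36 log units; beyond the scatter). In this assay it cannot be told from methylamino or chloro, with a 1.7-fold lower number from compound 3 to compound 4 (0.24 log units; within the scatter) and a 1.2-fold higher number from compound 1 to compound 4 (0.06 log units; within the scatter), so replacing methylamino, with one hydrogen-bond donor, by methoxy, with none, gives no readable change. No supporting data bear on the reason for these steps.

From the compounds shown here alone, whether a longer chain such as ethoxy, a dimethylamino group or a carboxylic acid would move the number further at this position stays open.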